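Swapping the Ring Substituent on a Shared Core

This account rests on a few compounds, and the source may have more. Where it says the series, first, only, none or still open, it means among the compounds named here.

Compound 1 `CCCCN(C)c1nc(C(F)(F)F)ccc1CNC(=O)C(C)c1ccc(NS(C)(=O)=O)c(F)c1`: 0.8 nM
Compound 2 `CC(C(=O)NCc1ccc(C(F)(F)F)nc1N1CCC(c2ccccc2)CC1)c1ccc(NS(C)(=O)=O)c(F)c1`: 0.6 nM
Compound 3 `CCCCOC1CCN(c2nc(C(F)(F)F)ccc2CNC(=O)C(C)c2ccc(NS(C)(=O)=O)c(F)c2)CC1`: 3.5 nM

Of the compounds shown here, three have been measured in a functional assay on CHO-K1 cells for antagonist activity at transient receptor potential cation channel subfamily V member 1 (Homo sapiens), read by FLIPR; a lower number here means a stronger inhibitor, a higher number a weaker inhibitor. Compound 1 gives 0.8 nM and compound 2 gives 0.6 nM; the step of a 1.3-fold lower number from compound 1 to compound 2 (0.12 log units; within the scatter) lies within the scatter. Compound 3 stands highest of the three: it is a 4.4-fold higher number from compound 1 to compound 3 (0.64 log units; beyond the scatter) and a 5.8-fold higher number from compound 2 to compound 3 (0.77 log units; beyond the scatter), both beyond the scatter.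

Compound 4 `CC(C(=O)NCc1ccc(C(F)(F)F)nc1N1CCC(CN(C)C)CC1)c1ccc(NS(C)(=O)=O)c(F)c1` is not yet measured. It differs from compound 3 in one place: (dimethylamino)methyl in place of butoxy on a saturated ring carbon. Going by the values given here, no measured step replaces butoxy by (dimethylamino)methyl, so there is no direct precedent. What does bear on the step is that the same saturated ring carbon tolerated phenyl well in compound 2 and gave a higher number with butoxy in compound 3, as the step of a 5.8-fold higher number from compound 2 to compound 3 (0.77 log units; beyond the scatter) shows; the group on that carbon therefore moves the number by a modest amount in this assay. Whether (dimethylamino)methyl behaves more like phenyl or more like butoxy cannot be told from these data, so a wide range is warranted. Compound 4 is expected to come out near compound 3, with the estimated step of a 1.2-fold lower number from compound 3 to compound 4 (0.07 log units; within the scatter). The estimate for compound 4 is 3 nM, with a range from 0.8 nM to 12 nM.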

Compound 4, inhibition constant: 2.1 nM
Compound 4: the middle estimate sits 1.4-fold (0.15 log units) above what was measured; measured number inside the range.
By their numbers in this assay, from the lowest: compounds 2 and 1 (each within the scatter of the next); then compounds 4 and 3 (each within the scatter of the next).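

In this assay, (dimethylamino)methyl and butoxy on the saturated ring carbon cannot be told apart (a 1.7-fold lower number from compound 3 to compound 4 (0.22 log units; within the scatter)), so at this position a nitrogen-bearing group without a ring reads the same as an oxygen-bearing one. The step from phenyl to (dimethylamino)methyl (a 3.5-fold higher number from compound 2 to compound 4 (0.54 log units; beyond the scatter)) lies beyond the scatter, as the step from phenyl to butoxy did, which places both groups without a ring on the same side of phenyl, though this rests on only these three groups. The full 4-((dimethylamino)methyl)piperidin-1-yl group also lies beyond the scatter from the open-chain butyl(methyl)amino group (a 2.6-fold higher number from compound 1 to compound 4 (0.42 log units; beyond the scatter)), a modest step, whereas 4-phenylpiperidin-1-yl stayed within the scatter of that open-chain group.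

Nothing among the data shown accounts for these steps. As far as these compounds go, it remains open whether the ring of phenyl itself sets it apart from the two chains, which a cyclohexyl or benzyl group on the same carbon would test, and whether a carboxylic acid or a primary amine there would read like the groups seen so far.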